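This account rests on a few compounds, and the source may have more. Where it says the series, first, only, none or still open, it means among the compounds named here.

Of the compounds shown here, three sharing one core have been tested in an ADME assay on L929 cells (Mus musculus) for cytotoxicity, read by resazurin assay, with a stated time of 72 h; on this read-out higher numbers stand for weaker inhibition and lower numbers for stronger inhibition. Compound 1 `CCCNC(=O)c1cccn1-c1ccc2c(c1)B(O)OC2` gives > 10 ug/mL, which is a limit of the assay rather than a number. Compound 2 `O=C(NC1CCCCC1)c1cccn1-c1ccc2c(c1)B(O)OC2` likewise gives only a limit, > 10 ug/mL. Compound 3 `O=C(NCc1ccccc1)c1cccn1-c1ccc2c(c1)B(O)OC2` also gives a limit, > 10 ug/mL. Compound 3 thus stands where all three values sit, at the limit of > 10 ug/mL in this assay, at which 3 of the 3 values shown sit. The steps a step that the two limits leave unreadable from compound 1 to compound 2, a step that the two limits leave unreadable from compound 1 to compound 3 and a step that the two limits leave unreadable from compound 2 to compound 3 therefore show neither size nor direction. Compound 4 `COc1ccc(CNC(=O)c2cccn2-c2ccc3c(c2)B(O)OC3)cc1` differs from compound 3 by methoxy in place of hydrogen on an aromatic carbon. With every measured step unreadable, no step beyond the scatter is expected in this assay in either direction, and compound 4 is expected to sit at the limit again. The estimate for compound 4 is 30 ug/mL, between 10 ug/mL and 100 ug/mL. The expected step is a step that the limit leaves unreadable from compound 3 to compound 4.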

Compound 4, half-maximal inhibitory concentration: > 10 ug/mL
Compound 4: a limit, no number (the forecaster's own chance of this, stated with the estimate: 85%); the middle value is on the limit's open side.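

Among the compounds shown here, compound 4, like compound 1, compound 2 and compound 3, gives only a limit, so no step among them can be read: the limit of > 10 ug/mL in this assay, at which 4 of the 4 values shown sit.

What the compounds shown leave open is where each actual value lies in this assay and whether the group on the amide nitrogen changes it.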